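This account rests on a few compounds, and the source may have more. Where it says the series, first, only, none or still open, it means among the compounds named here.

Measured compounds:
Compound 1, `Cc1noc2c1N=C(c1ccco1)CC(c1ccccc1)C2C(c1ccccc1)C1c2onc(C)c2N=C(c2ccco2)CC1c1ccccc1`, gives 35.9 ug/mL in a functional assay on MCF7 cells (Homo sapiens) for cytotoxicity, read by MTT assay, with a stated time of 48 h; a higher number here means a weaker inhibitor, a lower number a stronger inhibitor.
Compound 2, `Cc1ccc(C(C2c3onc(C)c3N=C(c3ccccc3)CC2c2ccccc2)C2c3onc(C)c3N=C(c3ccccc3)CC2c2ccccc2)cc1`, gives 41.9 ug/mL in this assay.
Compound 3, `Cc1ccc(C2CC(c3ccccc3)=Nc3c(C)noc3C2C(c2ccccc2)C2c3onc(C)c3N=C(c3ccccc3)CC2c2ccc(C)cc2)cc1`, gives 50.1 ug/mL in this assay.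

The number for compound 2 lies between those of compound 1 and compound 3, and all three lie within the usual scatter of one another, so the three cannot be told apart on these numbers.

Compound 4, `COc1ccc(C(C2c3onc(C)c3N=C(c3ccccc3)CC2c2ccccc2)C2c3onc(C)c3N=C(c3ccccc3)CC2c2ccccc2)cc1`, is not yet measured. It differs from compound 2 by methoxy in place of methyl on an aromatic carbon. For the measured compounds named here, no measured pair shows a change of this kind, so there is no step to lean on. Given how closely compound 1, compound 2 and compound 3 sit together, the step of a 1.0-fold higher number from compound 2 to compound 4 (0.00 log units; within the scatter) is expected to stay within the scatter, in no clear direction. Compound 4 is therefore estimated at 42 ug/mL, between 24 ug/mL and 75 ug/mL.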

Compound 4, half-maximal inhibitory concentration: 57.3 ug/mL
Compound 4: the middle estimate sits 1.4-fold (0.13 log units) below what was measured, and the stated range covers the measured number.
By their numbers in this assay, from the lowest: compounds 1, 2, 3 and 4 (each within the scatter of the next).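

Replacing 4-methylphenyl with 4-methoxyphenyl, on an aromatic carbon para to a large group, gives a 1.4-fold higher number from compound 2 to compound 4 (0.14 log units; within the scatter) in this assay and so does not separate the two compounds. For the compounds shown here, this is the first direct comparison at this position, and the added oxygen, counted as one hydrogen-bond acceptor, leaves the two numbers within the scatter. No measurement here bears on this result.

Going by these compounds, whether an amine or a carboxylic acid at this position would move the number beyond the scatter remains open. So does whether this swap would read the same on a different core.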